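Series notes: compound 3 to compound 4

The source may report more compounds than this note shows. Statements on the series, on what has been measured and on what is new or still open speak of the compounds shown alone.

Measured compounds:
Compound 1, `C/C(=N\OC(c1ccc(OCc2ccc3ccccc3n2)cc1)C1CCCCCC1)C(=O)O`: in a functional assay for inhibition of Polyunsaturated fatty acid 5-lipoxygenase (Homo sapiens) (a lower number here means a stronger inhibitor, a higher number a weaker inhibitor), compound 1 gives 13 nM.
Compound 2, `O=C(O)/C=N/OC(CC1CCCCC1)c1ccc(OCc2ccc3ccccc3n2)cc1`: in this assay compound 2 gives 27 nM.
Compound 3, `C/C(=N\OC(CC1CCCCC1)c1ccc(OCc2ccc3ccccc3n2)cc1)C(=O)O`: in this assay compound 3 gives 29 nM.

Compound 3 holds the highest of the three numbers, but its gap to compound 2 is small: a 1.1-fold higher number from compound 2 to compound 3 (0.03 log units; within the scatter), which changes only the acid-bearing group on the oxime oxygen. The gap to compound 1 is larger: a 2.2-fold higher number from compound 1 to compound 3 (0.35 log units; beyond the scatter), a change of the saturated group on the chain carbon bound to the aromatic carbon and the oxygen.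

Compound 4, `C/C(=N\OC(CCCc1ccc(F)cc1)c1ccc(OCc2ccc3ccccc3n2)cc1)C(=O)O`, is not yet measured. Its difference from compound 3 is 2-(4-fluorophenyl)ethyl in place of cyclohexyl on a saturated chain carbon, two bonds along the chain from an aromatic carbon and an oxygen. Within the data shown here, the only measured step touching this part of the molecule is the one from compound 1 to compound 3, which was modest. Among the measured compounds shown here, no measured step exchanges a saturated ring for an aromatic one or adds a fluorine, so the direction is uncertain. The expectation for compound 4 in this assay is therefore a step of about a 1.4-fold higher number from compound 3 to compound 4 (0.14 log units; within the scatter), close to no change beyond the scatter.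

Compound 4 is estimated at 40 nM, within 15 nM to 120 nM.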

Compound 4, half-maximal inhibitory concentration: 9 nM
Beside the measured number, compound 4's estimate is 4.4-fold (0.65 log units) above it; measured number below the stated range.
By their numbers in this assay, from the lowest: compounds 4 and 1 (each within the scatter of the next); then compounds 2 and 3 (each within the scatter of the next).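

In this assay, the position on the saturated chain carbon bound to an aromatic carbon and an oxygen accepts a chain ending in a fluorinated aromatic ring, and the step from cyclohexyl to 2-(4-fluorophenyl)ethyl is beyond the scatter (a 3.2-fold lower number from compound 3 to compound 4 (0.51 log units; beyond the scatter)). Until now, this position had only shown saturated rings, so this is the first sign that a saturated ring is not needed to reach the lowest numbers in the series: the comparison with cycloheptyl lies within the scatter (a 1.4-fold lower number from compound 1 to compound 4 (0.16 log units; within the scatter)), and 3-(4-fluorophenyl)propyl and cycloheptyl cannot be ranked against each other. No measurement at hand accounts for the gain over compound 3.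

The change from compound 3 to compound 4 alters the ring, the chain and the fluorine in one step, so the compounds shown do not separate their contributions; 3-phenylpropyl would isolate the fluorine, and 2-phenylethyl or 4-(4-fluorophenyl)butyl would test the chain. From the compounds shown here alone, whether the acid-bearing group on the oxime oxygen of compound 2 can be combined with 3-(4-fluorophenyl)propyl also stays open.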